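The source may report more compounds than this note shows. Statements on the series, on what has been measured and on what is new or still open speak of the compounds shown alone.

Compound 1 `CC1CCN(C2CCN(S(=O)(=O)c3cn(C)c(=O)n(C)c3=O)CC2)CC1`: > 10000 nM
Compound 2 `CC1CCN(C2CCN(S(=O)(=O)c3cccc4ccccc34)CC2)CC1`: > 10000 nM
Compound 3 `CC1CCN(C2CCN(S(=O)(=O)c3cccnc3Cl)CC2)CC1`: > 10000 nM

All three readings come from an ADME assay on HCT-116 cells (Homo sapiens) for cytotoxicity, read by CellTiter-Glo, with a stated time of 72 h (a lower number here means a stronger inhibitor, a higher number a weaker inhibitor), and each is a limit of the assay, not a number. Compound 3 stands with the other two at the limit of > 10000 nM in this assay, at which 3 of the 3 values shown sit, so the three cannot be ranked. Compound 4 `CC1CCN(C2CCN(S(=O)(=O)c3cccnc3)CC2)CC1` differs from compound 3 in one place: hydrogen in place of chloro on an aromatic carbon. The change is from 2-chloropyridin-3-yl to pyridin-3-yl. Going by the values given here, no measured pair shows a step of this kind. The expectation rests on compound 3 at > 10000 nM, a limit. The expected step, a step that the limit leaves unreadable from compound 3 to compound 4, is none beyond the scatter, in either direction. For compound 4 the estimated value is 15000 nM, with an expected range of 7000 nM to 30000 nM.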

Compound 4, half-maximal inhibitory concentration: > 10000 nM
Compound 4 gave a limit, no number; the forecaster's own chance of this, stated with the estimate: 85%; the middle value lies beyond the limit too.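

No step can be read from compound 3 to compound 4, as both readings are limits and not numbers: the limit of > 10000 nM in this assay, at which 4 of the 4 values shown sit.

The compounds shown leave open whether hydrogen in place of chloro on an aromatic carbon changes cytotoxicity at all.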